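Aryl swaps on the ring nitrogen: three measured, one pending

This account rests on a few compounds, and the source may have more. Where it says the series, first, only, none or still open, it means among the compounds named here.

compound 1 `COc1cccc(N2C(=O)CS/C2=N\c2csc(-c3ccc(Cl)cc3)c2)c1`: 24600 nM
compound 2 `O=C1CS/C(=N\c2csc(-c3ccc(Cl)cc3)c2)N1c1ccc(Cl)cc1`: 36600 nM
compound 3 `Cc1ccc(N2C(=O)CS/C2=N\c2csc(-c3ccc(Cl)cc3)c2)cc1`: 28900 nM

In a functional assay on HT-29 cells (Homo sapiens) for cytotoxicity, read by MTT assay, with a stated time of 72 h (on this read-out lower numbers stand for stronger inhibition and higher numbers for weaker inhibition), compound 1 holds the lowest of the three numbers, yet both steps away from it stay within the scatter: a 1.5-fold higher number from compound 1 to compound 2 (0.17 log units; within the scatter) and a 1.2-fold higher number from compound 1 to compound 3 (0.07 log units; within the scatter). Compound 2 and compound 3 likewise sit close, with a 1.3-fold lower number from compound 2 to compound 3 (0.10 log units; within the scatter). Compound 4 `COc1ccc(N2C(=O)CS/C2=N\c2csc(-c3ccc(Cl)cc3)c2)cc1OC` differs from compound 1 by methoxy in place of hydrogen on an aromatic carbon. Among the measured compounds shown here, no measured step adds a group to this ring; the steps that bear on it are all swaps of the aryl group on the amide-type nitrogen, and each stayed within the scatter, so no shift beyond the scatter is expected in this assay. Compound 4 is accordingly expected to give 26000 nM (range 12000 nM to 55000 nM). That estimate means an expected step of a 1.1-fold higher number from compound 1 to compound 4 (0.02 log units; within the scatter).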

Compound 4, half-maximal inhibitory concentration: 14100 nM
The estimate for compound 4 lay 1.8-fold (0.27 log units) above the measured number; the measured number falls inside the stated range.
By their numbers in this assay, from the lowest: compounds 4, 1, 3 and 2 (each within the scatter of the next, the first and the last beyond it).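

Within this assay methoxy in place of hydrogen on an aromatic carbon, ortho to a methoxy group and para to a large group, gives a 1.7-fold lower number from compound 1 to compound 4 (0.24 log units; within the scatter) and so stays within the scatter. Among the compounds shown here, this is the first step that adds a group to this ring instead of swapping the whole aryl group, and it behaves as those swaps did. No evidence on hand accounts for the size of this step.

Still open, from the compounds shown here alone, is whether an amine or a carboxylic acid at this place would move the number beyond the scatter. A longer chain in place of the methoxy leaves the same question.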